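A Third Aryl Amine on a Sulfonamide-Bearing Scaffold

The source may hold more compounds than are shown below. What is called first, only, known or untested is meant among the compounds shown, and "the series" means these compounds.

Compound 2 `COc1cc2ncnc(Nc3cccc(Cl)c3F)c2cc1OCCCCC(=O)Nc1ccc(S(N)(=O)=O)cc1` is one of two compounds examined in a functional assay on A-431 cells (Homo sapiens) for antiproliferative activity, read by MTT assay, with a stated time of 72 h (on this read-out higher numbers stand for weaker inhibition and lower numbers for stronger inhibition), and in this assay compound 2 gives 5560 nM. Among the compounds with values here, its only neighbour, compound 1 `COc1cc2ncnc(Nc3ccc(Br)cc3)c2cc1OCCCCC(=O)Nc1ccc(S(N)(=O)=O)cc1`, gives 6570 nM in this assay, and the step of a 1.2-fold lower number from compound 1 to compound 2 (0.07 log units; within the scatter) leaves the two within the scatter of each other, so compound 2 stands alongside compound 1 rather than apart from it. Compound 3 `COc1cc2ncnc(Nc3cc(F)c(F)c(F)c3)c2cc1OCCCCC(=O)Nc1ccc(S(N)(=O)=O)cc1` differs from compound 2 in one place: 3,4,5-trifluorophenyl in place of 3-chloro-2-fluorophenyl on a nitrogen on an aromatic ring. Within the data shown here, the single measured step that bears on this change is the earlier exchange of the group on the same nitrogen, a 1.2-fold lower number from compound 1 to compound 2 (0.07 log units; within the scatter), which did not move the number beyond the scatter. On that basis no step beyond the scatter is expected in this assay, in no firm direction, and the estimate means a 1.1-fold higher number from compound 2 to compound 3 (0.03 log units; within the scatter). Compound 3 is therefore expected to give 6000 nM, within a range from 2500 nM to 15000 nM.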

Compound 3, half-maximal inhibitory concentration: 23400 nM
Compound 3: middle estimate off by 3.9-fold (0.59 log units), on the low side; measured number outside the range, above it.
By their numbers in this assay, from the lowest: compounds 2 and 1 (each within the scatter of the next); then compound 3.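

In this assay the group on the nitrogen proved able to move the number after all: the 3,4,5-trifluorophenyl group gives a 4.2-fold higher number from compound 2 to compound 3 (0.62 log units; beyond the scatter) and, against the 4-bromophenyl group, a 3.6-fold higher number from compound 1 to compound 3 (0.55 log units; beyond the scatter) on the same scaffold. Among the three compounds, therefore, a change of this aryl group can leave the number within the scatter, as between compound 1 and compound 2, or carry it beyond the scatter, as with compound 3, whose number is the highest of the three. No measurement shown explains why the 3,4,5-trifluorophenyl group differs from the other two aryl groups. The compounds shown leave open whether a plain phenyl, a 3-ethynylphenyl or a 4-methoxyphenyl group would stay with compound 1 and compound 2 or move towards compound 3. They also leave open whether the same step would appear with a shorter chain or with a carboxylic acid in place of the sulfonamide.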